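Bromo for chloro on the sulfonyl aryl: cytotoxicity

The source may report more compounds than this note shows. Statements on the series, on what has been measured and on what is new or still open speak of the compounds shown alone.

Measured in an ADME assay on L02 cells (Homo sapiens) for cytotoxicity, read by MTT assay, with a stated time of 24 h; on this read-out lower numbers stand for stronger inhibition and higher numbers for weaker inhibition:
compound 1 `O=C1/C(=C/c2ccccc2F)CN(S(=O)(=O)c2ccc(Cl)cc2)C/C1=C\c1ccccc1F` gives 14100 nM
compound 2 `O=C1/C(=C/c2ccccc2F)CN(S(=O)(=O)c2ccc(Br)cc2)C/C1=C\c1ccccc1F` gives 16200 nM
compound 3 `O=C1/C(=C/c2ccc(F)cc2)CN(S(=O)(=O)c2ccc(Cl)cc2)C/C1=C\c1ccc(F)cc1` gives 15500 nM

Compound 2 differs from compound 1 by bromo in place of chloro on an aromatic carbon, and in this assay this made a 1.1-fold higher number from compound 1 to compound 2 (0.06 log units; within the scatter). Compound 3 and compound 1 have the same atoms joined differently; the difference between the two cores is not broken down here. Within the data shown here, compound 4 `O=C1/C(=C/c2ccc(F)cc2)CN(S(=O)(=O)c2ccc(Br)cc2)C/C1=C\c1ccc(F)cc1` is obtained from compound 3 by bromo in place of chloro on an aromatic carbon, the same change as the one from compound 1 to compound 2, with the place described in identical words. Since that earlier step stayed within the scatter, the step to compound 4 in this assay is expected to be similarly small, a 1.1-fold higher number from compound 3 to compound 4 (0.04 log units; within the scatter). Compound 4 is therefore estimated at 17000 nM, between 9000 nM and 32000 nM.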

Compound 4, half-maximal inhibitory concentration: 16400 nM
Compound 4: middle estimate off by 1.0-fold (0.02 log units), on the high side; low and high end bracket the measured number.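

Bromo in place of chloro on the core of compound 3 gave a 1.1-fold higher number from compound 3 to compound 4 (0.02 log units; within the scatter) in this assay. Set beside the earlier step on the core of compound 1, it shows no difference between the two cores: the same change on two cores in this assay, a 1.1-fold higher number (0.06 log units; within the scatter) from compound 1 to compound 2 and a 1.1-fold higher number (0.02 log units; within the scatter) from compound 3 to compound 4, 1.1-fold (0.04 log units) apart, within the scatter of two such steps. This shows that 4-chlorophenyl to 4-bromophenyl on the sulfonyl group left the number within the scatter on both cores, but two such small steps do not show that a larger step would carry over in the same way, or that this one would hold on any other core.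

Going by these compounds, it remains open how an amine or a carboxylic acid in place of the halogen would read in this assay. On these data alone, it also remains open whether such a change would give the same step on both cores.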